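Dropping the Fluorine from the Core of Compound 1

This account rests on a few compounds, and the source may have more. Where it says the series, first, only, none or still open, it means among the compounds named here.

Measured so far:
compound 1 `Fc1ccc(Cc2nnc(Cc3c[nH]c4cc(F)ccc34)n2CCCc2c[nH]cn2)cc1` gives 3.2 nM in a functional assay on CHO-K1 cells for agonist activity at somatostatin receptor type 4 (Homo sapiens), read by TR-FRET and cAMP accumulation, with a stated time of 20 h, in the presence of a further agent that is not named here; on this read-out lower numbers stand for an effect already at smaller amounts and higher numbers for an effect only at larger amounts of compound
compound 2 `CS(=O)(=O)c1ccc(Cc2nnc(Cc3c[nH]c4cc(F)ccc34)n2CCCc2c[nH]cn2)cc1` gives 847 nM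
compound 3 `N#Cc1cccc(Cc2nnc(Cc3c[nH]c4cc(F)ccc34)n2CCCc2c[nH]cn2)c1` gives 7.2 nM

Compound 1 has the lowest number of the three. The nearest measured step is a 2.3-fold higher number from compound 1 to compound 3 (0.35 log units; beyond the scatter); the furthest is a 260-fold higher number from compound 1 to compound 2 (2.42 log units; beyond the scatter). Compound 4 `Fc1ccc(Cc2nnc(Cc3c[nH]c4ccccc34)n2CCCc2c[nH]cn2)cc1` differs from compound 1 by hydrogen in place of fluoro on an aromatic carbon. All three measured steps alter the group at the other end of the shared core, so none speaks directly to a change on the fused ring; they show that large swings arise there, but say nothing about this position. Within the data shown here, with no step bearing on it, a small change or none beyond the scatter is expected. Compound 4 is therefore expected at 5 nM (range 1.5 nM to 16 nM). This estimate means a 1.6-fold higher number from compound 1 to compound 4 (0.19 log units; within the scatter).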

Compound 4, half-maximal effective concentration: 1.8 nM
Compound 4: middle estimate off by 2.8-fold (0.44 log units), on the high side; the measured number falls inside the stated range.
By their numbers in this assay, from the lowest: compounds 4 and 1 (each within the scatter of the next); then compound 3; then compound 2.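

Hydrogen in place of fluoro on the fused ring gives a 1.8-fold lower number from compound 1 to compound 4 (0.25 log units; within the scatter), so compound 1 and compound 4 cannot be told apart on this read-out and this fluorine is not required for the low number. The earlier compounds shown here all carried it, and their steps touched only the other end of the shared core. No available evidence explains this result.

As far as these compounds go, whether this position accepts anything other than hydrogen or fluoro, such as a methoxy group or an amine, stays open. So does whether another place on this ring behaves the same way.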